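The compounds below may be only part of what the source reports. "The series", "measured", "known", "first", "only" and "open" are said of these compounds alone.

Measured so far in an assay for inhibition of very long chain fatty acid elongase 6 (Homo sapiens); on this read-out lower numbers stand for stronger inhibition and higher numbers for weaker inhibition:
compound 1 `O=C1Nc2ccc(-n3cncn3)cc2C(CNC(=O)c2ccc(F)cc2)(C(F)(F)F)O1` gives 572 nM
compound 2 `Cc1cccc(C(=O)NCC2(C(F)(F)F)OC(=O)Nc3ccc(Cl)cc32)c1` gives 437 nM
compound 3 `O=C1Nc2ccc(Cl)cc2C(CNC(=O)c2ccc(C(F)(F)F)cc2)(C(F)(F)F)O1` gives 813 nM

On these three numbers compound 1 stands second highest; its nearest neighbour is compound 2 and its furthest is compound 3, and both of those gaps lie within the usual scatter, so the three compounds cannot be told apart on potency.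

Among the compounds with values here, the only one-place step measured here runs a 1.9-fold higher number from compound 2 to compound 3 (0.27 log units; within the scatter), an exchange of the group on a carbonyl carbon that stays within the scatter.

Compound 4 `O=C1Nc2ccc(-n3ccccc3=O)cc2C(CNC(=O)c2ccc(F)cc2)(C(F)(F)F)O1` has not been measured. Compared with compound 1 it carries a group of 7 heavy atoms (5 carbon, 1 nitrogen, 1 oxygen; one six-membered aromatic ring with 1 hetero atom) in place of a group of 5 heavy atoms (2 carbon, 3 nitrogen; one five-membered aromatic ring with 3 hetero atoms), on an aromatic carbon. Within the data shown here, this change sits on the fused ring system of the shared core rather than on the carbonyl carbon, so the measured step from compound 2 to compound 3 does not speak to it directly, and no measured pair shows what exchanging a ring on this aromatic carbon does. With nothing pointing either way, the expectation is a number close to that of compound 1, with no step beyond the scatter in this assay. Compound 4 is therefore estimated at 600 nM, in a range from 200 nM to 1800 nM. The step this estimate means, a 1.0-fold higher number from compound 1 to compound 4 (0.02 log units; within the scatter), is expected to be small.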

Compound 4, half-maximal inhibitory concentration: 106 nM
Compound 4: middle estimate off by 5.7-fold (0.75 log units), on the high side; the whole stated range lies above it.
By their numbers in this assay, from the lowest: compound 4; then compounds 2, 1 and 3 (each within the scatter of the next).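

In this assay the exchange of the 1H-1,2,4-triazol-1-yl group for a six-membered aromatic ring with one hetero atom and a double bond outside the ring gives a 5.4-fold lower number from compound 1 to compound 4 (0.73 log units; beyond the scatter), and this is the first step among the compounds shown that lies beyond the scatter. Within the data shown here, it shows that this aromatic carbon, part of a fused system of two rings, is a place where the choice of ring can move the number clearly, which the single earlier step on a carbonyl carbon could not show. The change alters several things at once, including ring size, the number of nitrogen atoms and the presence of oxygen, and no measurement available here explains the step.

Among these compounds, with only this one pair, it remains open which of those differences matters, and a plain phenyl ring or a morpholine on the same carbon would help to separate them. Going by these compounds, it is also open whether the new ring would give a step of similar size with the 3-methylphenyl or 4-(trifluoromethyl)phenyl group on the carbonyl carbon in place of the 4-fluorophenyl group.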